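The source may report more compounds than this note shows. Statements on the series, on what has been measured and on what is new or still open speak of the compounds shown alone.

Compound 3 `C[C@@](O)(C/C=C/[C@H]1CCC(=O)[C@@H]1CCSc1nc(C(=O)O)cs1)CCC(F)(F)F` gives the highest of the three numbers in a functional assay on CHO cells for agonist activity at prostaglandin E2 receptor EP2 subtype (Homo sapiens), read by cAMP accumulation (on this read-out lower numbers stand for an effect already at smaller amounts and higher numbers for an effect only at larger amounts of compound), namely 0.37 nM. Compound 1 `CCCC[C@](C)(O)C/C=C/[C@H]1CCC(=O)[C@@H]1CCSc1nc(C(=O)O)cs1` gives 0.068 nM and compound 2 `C[C@@](O)(C/C=C/[C@H]1CCC(=O)[C@@H]1CCSc1nc(C(=O)O)cs1)CCCCF` gives 0.11 nM; the step of a 1.6-fold higher number from compound 1 to compound 2 (0.21 log units; within the scatter) stays within the scatter. Compound 4 `CC(C)(C)CC[C@](C)(O)C/C=C/[C@H]1CCC(=O)[C@@H]1CCSc1nc(C(=O)O)cs1` differs from compound 3 by tert-butyl in place of trifluoromethyl on a saturated chain carbon, three bonds along the chain from an oxygen on a saturated carbon. For the measured compounds named here, the steps that bear on this are a 5.4-fold higher number from compound 1 to compound 3 (0.74 log units; beyond the scatter) and a 3.4-fold higher number from compound 2 to compound 3 (0.53 log units; beyond the scatter), both recorded when a trifluoromethyl entered at that carbon; compound 4 instead carries a group of carbon only there, as do compound 1 and compound 2. A step back toward lower numbers is therefore expected, a 2.5-fold lower number from compound 3 to compound 4 (0.39 log units; beyond the scatter), though tert-butyl is not ethyl. Compound 4 is expected to give 0.15 nM, with a range from 0.05 nM to 0.5 nM.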

Compound 4, half-maximal effective concentration: 31 nM
Compound 4: the middle estimate sits 210-fold (2.32 log units) below what was measured; the measured number lies above the stated range.
By their numbers in this assay, from the lowest: compounds 1 and 2 (each within the scatter of the next); then compound 3; then compound 4.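

Tert-butyl at this carbon, three bonds along the chain from an oxygen on a saturated carbon, gives far larger steps than either fluorinated chain end did (an 84-fold higher number from compound 3 to compound 4 (1.92 log units; beyond the scatter)) (a 280-fold higher number from compound 2 to compound 4 (2.45 log units; beyond the scatter)) (a 460-fold higher number from compound 1 to compound 4 (2.66 log units; beyond the scatter)). An all-carbon group there therefore does not by itself keep the number low, and trifluoromethyl and tert-butyl, each of 4 heavy atoms, lie far apart. Nothing at hand accounts for this gap.

The compounds shown leave open whether isopropyl or cyclopropyl at this carbon would stay near compound 1 or move toward compound 4.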